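The compounds below may be only part of what the source reports. "The series", "measured", "known", "first", "only" and "open" are said of these compounds alone.

Working notes on the thiazolyl hydrazone series.

Three compounds have been run in an ADME assay on THP-1 cells (Homo sapiens) for cytotoxicity, read by MTT assay, tested at 50 ug/mL; on this read-out lower numbers stand for less inhibition and higher numbers for more inhibition at the one concentration tested (going by the name of the read-out). Compound 1, `Clc1ccc(-c2csc(N/N=C/c3ccc(-n4ccnc4)cc3)n2)c(Cl)c1`, gives 28.8%. Compound 2, `Cc1ccc(-c2csc(N/N=C/c3ccc(-n4ccnc4)cc3)n2)cc1`, gives 36%. Compound 3, `Clc1ccc(-c2csc(N/N=C/c3ccc(-n4cncn4)cc3)n2)c(Cl)c1`, gives 8.9%. The change from compound 1 to compound 2, (4-methylphenyl in place of 2,4-dichlorophenyl on an aromatic carbon), is within the scatter: a number 7.2 percentage points higher from compound 1 to compound 2 (within the scatter). The change of the core from compound 1 to compound 3, (1H-1,2,4-triazol-1-yl in place of 1H-imidazol-1-yl on an aromatic carbon), is beyond the scatter: a number 19.9 percentage points lower from compound 1 to compound 3 (beyond the scatter).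

Compound 4, `Cc1ccc(-c2csc(N/N=C/c3ccc(-n4cncn4)cc3)n2)cc1`, is the only one not yet measured. It differs from compound 3 by 4-methylphenyl in place of 2,4-dichlorophenyl on an aromatic carbon, which is the same change as that from compound 1 to compound 2, and it occurs twice among the four compounds. The place lines of both changes read the same word for word, so the two steps are directly comparable; the cores of the two pairs differ as told by the difference between compound 1 and compound 3.

The step from compound 3 to compound 4 is expected to be small, a number 7.1 percentage points higher from compound 3 to compound 4 (within the scatter), because the same change gave a number 7.2 percentage points higher from compound 1 to compound 2 (within the scatter). This rests on one measured pair only, so the spread allowed is wide. Compound 4 is expected to give about 16% in this assay, with a range from 4% to 30%.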

Compound 4, a percentage reported as inhibition, at one concentration (the size of the read-out at that concentration, not a potency): 13.6%
Compound 4: middle estimate off by 2.4 percentage points, on the high side; the measured number falls inside the stated range.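

In this assay the exchange of 2,4-dichlorophenyl for 4-methylphenyl gives a number 4.7 percentage points higher from compound 3 to compound 4 (within the scatter), and this exchange reads the same on both cores: the same change on two cores in this assay, a number 7.2 percentage points higher (within the scatter) from compound 1 to compound 2 and a number 4.7 percentage points higher (within the scatter) from compound 3 to compound 4, 2.5 percentage points apart, within the scatter of two such steps. The exchange of 1H-imidazol-1-yl for 1H-1,2,4-triazol-1-yl gives a number 22.4 percentage points lower from compound 2 to compound 4 (beyond the scatter), and it too reads the same whichever aryl group is present: the same change on two cores in this assay, a number 19.9 percentage points lower (beyond the scatter) from compound 1 to compound 3 and a number 22.4 percentage points lower (beyond the scatter) from compound 2 to compound 4, 2.5 percentage points apart, within the scatter of two such steps. Across these four compounds the two changes therefore behave as independent of each other, with the azole exchange accounting for the steps beyond the scatter and the aryl exchange for none, but this rests on two pairs per change in a single assay and shows neither that the agreement extends to other cores nor why either step has the size it has.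

The compounds shown cover only two aryl groups and two azoles, so it remains open whether the same independence holds with an amine, a carboxylic acid or a longer chain at the place of the aryl group. Going by these compounds, it is equally open whether the lower numbers of the triazole pair persist at other concentrations, since each compound is read here at one concentration only.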